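The compounds below may be only part of what the source reports. "The series", "measured", "known", "first", "only" and "open" are said of these compounds alone.

In a functional assay on the whole organism with Mus musculus as the target, in the maximal electroshock model, at a dose of 50 mg/kg by the oral route (on this read-out higher numbers stand for more inhibition at the one dose given (going by the name of the read-out) and lower numbers for less inhibition), compound 1 `CCCN(CCC)CCCCOc1ccccc1/C=C/c1ccccc1` gives 0%, and compound 2 `CN(C)CCN(C)CCCCOc1ccccc1/C=C/c1ccccc1` gives 0%. Going by the values given here, the only measured step, no change at the digits printed from compound 1 to compound 2 (within the scatter), stays within the scatter, so compound 2 stands level with compound 1 on this read-out. Compound 3 `O=C(O)C1CCCN(CCCCOc2ccccc2/C=C/c2ccccc2)C1` differs from compound 2 by 3-carboxypiperidin-1-yl in place of (2-(dimethylamino)ethyl)(methyl)amino on a saturated chain carbon, four bonds along the chain from an oxygen on an aromatic ring. Among the compounds with values here, no measured step involves a ring or a carboxylic acid at this place, so the available evidence is thin. Since the step of no change at the digits printed from compound 1 to compound 2 (within the scatter) brought no change, compound 3 is expected to shift by no change at the digits printed from compound 2 to compound 3 (within the scatter), nothing beyond the scatter. Compound 3 is therefore estimated at 0%, within a range from 0% to 10%.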

Compound 3, a percentage reported as inhibition, in the whole organism at one dose (the size of the read-out at that dose, not a potency): 12.5%
For compound 3 the middle estimate is 12.5 percentage points below the measured one, and the stated range ends below it.
By their numbers in this assay, from the lowest: compounds 1 and 2 (each within the scatter of the next); then compound 3.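

In this assay the read-out shows a number 12.5 percentage points higher from compound 2 to compound 3 (beyond the scatter) and a number 12.5 percentage points higher from compound 1 to compound 3 (beyond the scatter) once 3-carboxypiperidin-1-yl sits on the saturated chain carbon, four bonds along the chain from an oxygen on an aromatic ring. The two groups without a ring had stayed level, so this place does respond to the group it carries, if modestly. Nothing measured accounts for the step. The compounds shown leave open whether the ring or the carboxylic acid carries the step: piperidin-1-yl without the acid, or the methyl ester of the acid, would separate the two.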